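The source may report more compounds than this note shows. Statements on the series, on what has been measured and on what is new or still open speak of the compounds shown alone.

Working notes on the series

Compound 2 `COc1ccc(/C=C2\SC(=O)N(Cc3ccc(C(=O)O)cc3)C2=O)cc1` gives 44000 nM in a functional assay on A549 cells (Homo sapiens) for cytotoxicity, read by MTT assay, with a stated time of 24 h (on this read-out higher numbers stand for weaker inhibition and lower numbers for stronger inhibition), and stands second highest of the three numbers in hand. Compound 1 `COc1cccc(/C=C2\SC(=O)N(Cc3ccc(C(=O)O)cc3)C2=O)c1` gives 55000 nM in this assay, and compound 3 `O=C(O)c1ccc(CN2C(=O)S/C(=C\c3ccc(F)cc3)C2=O)cc1` gives 36000 nM. The measured steps, a 1.3-fold lower number from compound 1 to compound 2 (0.10 log units; within the scatter), a 1.5-fold lower number from compound 1 to compound 3 (0.18 log units; within the scatter) and a 1.2-fold lower number from compound 2 to compound 3 (0.09 log units; within the scatter), all fall within the scatter, so the three aryl variants on the double-bonded chain carbon are not separated by these data.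

Compound 4 `O=C(O)c1ccc(CN2C(=O)S/C(=C\c3ccco3)C2=O)cc1` differs from compound 2 by furan-2-yl in place of 4-methoxyphenyl on a double-bonded chain carbon bound to a double-bonded ring carbon. For the measured compounds named here, no measured step replaces the whole six-membered aryl by a five-membered ring; the steps that bear on it only loosely are the three aryl exchanges above, and each of them left this assay unchanged beyond the scatter. The expectation is therefore a step of no change at the digits printed from compound 2 to compound 4 (within the scatter), in no direction beyond the scatter. Compound 4 is estimated at 44000 nM in this assay, with a range from 20000 nM to 95000 nM.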

Compound 4, half-maximal inhibitory concentration: 76000 nM
Compound 4: middle estimate off by 1.7-fold (0.24 log units), on the low side; low and high end bracket the measured number.
By their numbers in this assay, from the lowest: compounds 3, 2, 1 and 4 (each within the scatter of the next, the first and the last beyond it).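

In this assay, this position, on a double-bonded chain carbon bound to a double-bonded ring carbon, now gives its first step beyond the scatter, a modest one, when furan-2-yl replaces 4-fluorophenyl (a 2.1-fold higher number from compound 3 to compound 4 (0.32 log units; beyond the scatter)). The exchanges for the two methoxyphenyl groups stay within the scatter (a 1.7-fold higher number from compound 2 to compound 4 (0.24 log units; within the scatter); a 1.4-fold higher number from compound 1 to compound 4 (0.14 log units; within the scatter)), so furan-2-yl is separated from 4-fluorophenyl only, not from 4-methoxyphenyl or 3-methoxyphenyl. Nothing in hand accounts for the step.

Open, from the compounds shown here alone, is whether thiophen-2-yl or pyridin-3-yl at this place would stay with furan-2-yl or with the six-membered aryl groups. Also open, going by these compounds, is whether an amine on the aryl group would carry the number beyond the scatter from compound 2.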